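Propyl to Isopropyl on the Aryl Ring: Expected Effect

A few compounds are considered here, and "the series" means these few. Any claim that something is new, unique, unknown or untested is made for them only; others in the source may bear on it.

Compound 2 `CCCc1ccccc1-n1nc(C)c2c1NC(=O)[C@H](C)S[C@@H]2c1ccc(Oc2ccccc2)cc1` carries a propyl group on an aromatic carbon of a six-membered aromatic ring of carbon only. In an assay on isolated protein for agonist activity at Bile acid receptor (Homo sapiens), read by AlphaScreen, with a stated time of 30 min (on this read-out lower numbers stand for an effect already at smaller amounts and higher numbers for an effect only at larger amounts of compound), compound 2 gives 1100 nM, level with compound 1 `CCc1ccccc1-n1nc(C)c2c1NC(=O)[C@H](C)S[C@@H]2c1ccc(Oc2ccccc2)cc1`, which in this assay gives 1100 nM. The step of no change at the digits printed from compound 1 to compound 2 (within the scatter) shows that adding methyl in place of hydrogen on a saturated chain carbon, two bonds along the chain from an aromatic carbon, left the read-out where it was. Compound 3 `Cc1nn(-c2ccccc2C(C)C)c2c1[C@@H](c1ccc(Oc3ccccc3)cc1)S[C@@H](C)C(=O)N2` has not been measured; it differs from compound 2 by isopropyl in place of propyl on an aromatic carbon, the same atoms joined differently. Going by the values given here, only the step from compound 1 to compound 2 bears on this change, and it was flat, so no step beyond the scatter is expected in this assay; the expected step is no change at the digits printed from compound 2 to compound 3 (within the scatter). Compound 3 is therefore estimated at 1100 nM, with a likely range from 500 nM to 2500 nM.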

Compound 3, half-maximal effective concentration: 1900 nM
Estimate against measurement, compound 3: 1.7-fold (0.24 log units) below; measured number inside the range.
By their numbers in this assay, from the lowest: compounds 1, 2 and 3 (each within the scatter of the next).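

Compound 3 adds a new kind of change at this position: the same three carbons are joined differently, rather than the chain being extended. In this assay, isopropyl in place of propyl on this aromatic carbon, ortho to a large group, gives a 1.7-fold higher number from compound 2 to compound 3 (0.24 log units; within the scatter), while methyl in place of hydrogen on the chain carbon bound to the ring gives a 1.7-fold higher number from compound 1 to compound 3 (0.24 log units; within the scatter), so this read-out does not separate the straight chains from the branched one. No other measurement is at hand that could explain this result.

Going by these compounds, whether this flat picture holds for a longer chain such as butyl remains open. So does the effect of a different kind of group at this position, such as an amine or a carboxylic acid.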